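This account rests on a few compounds, and the source may have more. Where it says the series, first, only, none or still open, it means among the compounds named here.

In a functional assay on HepG2 cells (Homo sapiens) for antiproliferative activity, read by MTT assay, with a stated time of 48 h (on this read-out lower numbers stand for stronger inhibition and higher numbers for weaker inhibition), compound 1 `COc1ccc(/C=C/c2cc(OC)cc(OC)c2/C=C/C(=O)c2ccc(Cl)c(Cl)c2)cc1` gives 10.8 ug/mL. Among the three numbers measured so far, compound 1 takes the second highest place, though every gap is within the scatter: its nearest neighbour is compound 3 `COc1ccc(/C=C/c2cc(OC)cc(OC)c2/C=C/C(=O)c2cccc(Cl)c2)cc1`, which gives 9.5 ug/mL in this assay, and its furthest is compound 2 `CCCCOc1ccc(C(=O)/C=C/c2c(/C=C/c3ccc(OC)cc3)cc(OC)cc2OC)cc1`, which gives 12.9 ug/mL there.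

The three measured steps are all small. The step of a 1.1-fold lower number from compound 1 to compound 3 (0.06 log units; within the scatter) removes a chloro from the shared core's aryl ketone; the step of a 1.2-fold higher number from compound 1 to compound 2 (0.08 log units; within the scatter) and the step of a 1.4-fold lower number from compound 2 to compound 3 (0.13 log units; within the scatter) swap the whole aryl group on the carbonyl carbon. None of them moves the number beyond the scatter.

Compound 4 `COc1ccc(/C=C/c2cc(OC)cc(OC)c2/C=C/C(=O)c2ccc(Cl)cc2)cc1` differs from compound 1 by hydrogen in place of chloro on an aromatic carbon. The step from compound 1 to compound 3, which also removes a chloro from the same ring, is the closest guide and was within the scatter, so no step beyond the scatter is expected here either, in either direction. Compound 4 is therefore estimated at 10.5 ug/mL in this assay, with a likely range from 6 ug/mL to 19 ug/mL, an expected step of a 1.0-fold lower number from compound 1 to compound 4 (0.01 log units; within the scatter).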

Compound 4, half-maximal inhibitory concentration: 13.6 ug/mL
Compound 4: the middle estimate sits 1.3-fold (0.11 log units) below what was measured; the measured number falls inside the stated range.
By their numbers in this assay, from the lowest: compounds 3, 1, 2 and 4 (each within the scatter of the next).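

With compound 4, each of the two chloro groups of the 3,4-dichlorophenyl has now been taken away in turn, and the removal of the chloro at this place, ortho to a chloro group, gives a 1.3-fold higher number from compound 1 to compound 4 (0.10 log units; within the scatter). The position of a single chloro cannot be told from these numbers, with 3-chlorophenyl and 4-chlorophenyl separated by a 1.4-fold higher number from compound 3 to compound 4 (0.16 log units; within the scatter), and 4-butoxyphenyl and 4-chlorophenyl cannot be told apart either, at a 1.1-fold higher number from compound 2 to compound 4 (0.02 log units; within the scatter). No further measurement is at hand that bears on this result.

From the compounds shown here alone, the aryl group on the carbonyl carbon carries only chloro or butoxy in these compounds, so it remains open whether a plain phenyl, an amine or a carboxylic acid there would move the number beyond the scatter. Going by these compounds, it also remains open whether a change to the shared core, such as hydroxy in place of its methoxy groups, would do so.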